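Adding a Second Methoxy Group to Compound 2

The compounds below may be only part of what the source reports. "The series", "measured", "known", "first", "only" and "open" are said of these compounds alone.

Of the compounds shown here, two have been measured in a functional assay on CCRF-CEM cells (Homo sapiens) for inhibition, with a stated time of 3 days; on this read-out lower numbers stand for stronger inhibition and higher numbers for weaker inhibition. Compound 1 `Cc1c(C(=O)/C=C/c2cccc([N+](=O)[O-])c2)[n+]([O-])c2ccccc2[n+]1[O-]` gives 15800 nM, and compound 2 `COc1ccc(/C=C/C(=O)c2c(C)[n+]([O-])c3ccccc3[n+]2[O-])cc1` gives 27600 nM. Compound 2 has the highest of these two numbers, yet its gap to compound 1 is within the usual scatter, so the two cannot be told apart. Compound 3 `COc1ccc(/C=C/C(=O)c2c(C)[n+]([O-])c3ccccc3[n+]2[O-])cc1OC` differs from compound 2 by methoxy in place of hydrogen on an aromatic carbon. Going by the values given here, no measured pair shows this change, so no step beyond the scatter is expected in this assay in either direction. For compound 3 the expected value is 25000 nM, within 10000 nM to 60000 nM. The expected step is a 1.1-fold lower number from compound 2 to compound 3 (0.04 log units; within the scatter).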

Compound 3, half-maximal inhibitory concentration: 19200 nM
Estimate against measurement, compound 3: 1.3-fold (0.11 log units) above; the measured number falls inside the stated range.
By their numbers in this assay, from the lowest: compounds 1, 3 and 2 (each within the scatter of the next).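

In this assay, going by these compounds alone, methoxy in place of hydrogen on an aromatic carbon, ortho to a methoxy group and meta to a large group, gives a 1.4-fold lower number from compound 2 to compound 3 (0.16 log units; within the scatter), the first single-place step. At this position, then, the added methoxy produces no change that can be told apart from the scatter. Nothing measured here offers an explanation for this result.

On these data alone, whether an amine, a carboxylic acid or a longer chain such as butoxy at this position would give a step beyond the scatter remains open.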